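A few compounds are considered here, and "the series" means these few. Any claim that something is new, unique, unknown or untested is made for them only; others in the source may bear on it.

Two thioureas built on one shared core have been measured so far. Compound 1, `COc1cc(CNC(=S)NCC(COC(=O)C(C)(C)C)Cc2ccc(C)c(C)c2)ccc1O`, gives in an assay on isolated protein for binding affinity to transient receptor potential cation channel subfamily V member 1 (Rattus norvegicus) (a higher number here means a weaker inhibitor, a lower number a stronger inhibitor), a value of 17.4 nM. Compound 2, `Cc1ccc(CC(CN/C(S)=N/Cc2ccc(NS(C)(=O)=O)cc2)COC(=O)C(C)(C)C)cc1C`, sits alongside it: in this assay compound 2 gives 29.3 nM, and the gap between the two numbers lies within the scatter of repeated measurements, so no ranking of the two can be drawn from them. The next compound, compound 3, `CCCS(=O)(=O)Nc1ccc(C/N=C(\S)NCC(COC(=O)C(C)(C)C)Cc2ccc(C)c(C)c2)cc1`, has not yet been measured. It differs from compound 2 in one place: ethyl in place of hydrogen on a saturated chain carbon bound to a sulfonyl sulfur. Among the measured compounds shown here, no step between measured compounds is available for this change, so its effect has to be guessed. A modest gain in affinity for compound 3 is expected, within the size of a 2.0-fold lower number from compound 2 to compound 3 (0.29 log units; within the scatter), with a real chance that the number stays within the scatter of compound 2. Compound 3 is therefore estimated at 15 nM, in a range from 5 nM to 60 nM.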

Compound 3, inhibition constant: 313 nM
Compound 3: the middle estimate sits 21-fold (1.32 log units) below what was measured; measured number above the stated range.
By their numbers in this assay, from the lowest: compounds 1 and 2 (each within the scatter of the next); then compound 3.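

In this assay, ethyl in place of hydrogen on a saturated chain carbon bound to a sulfonyl sulfur gives an 11-fold higher number from compound 2 to compound 3 (1.03 log units; beyond the scatter). Among the compounds shown here, this is the first step that lies beyond the scatter, and it shows that this position is sensitive: going from methylsulfonyl to propylsulfonyl costs a large part of the affinity, whereas the two earlier compounds could not be told apart. Nothing measured here gives a reason for this loss.

Going by these compounds, a single step cannot show whether the loss sets in gradually or only at a certain chain length, so ethylsulfonyl, isopropylsulfonyl and butylsulfonyl remain open cases. On these data alone, it also remains open how a chain ending in an amine or a carboxylic acid would fare at this position.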